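Shifting fluorines on the sulfonyl aryl of compound 1

The source may hold more compounds than are shown below. What is called first, only, known or untested is meant among the compounds shown, and "the series" means these compounds.

Compound 1, `O=S(=O)(c1ccc(F)c(F)c1)c1cnc2c(F)cccc2c1-c1ccc(Cl)cc1`, gives 0.28 mL/min in an ADME assay on microsomes from liver (Homo sapiens) for metabolic stability, tested at 2.5 uM; a higher number here means faster removal of the compound, a lower number slower removal.
Compound 2, `O=S(=O)(c1ccc(F)c(F)c1)c1cnc2c(F)cccc2c1-c1ccc(F)cc1`, gives 0.78 mL/min in this assay.
Compound 3, `O=S(=O)(c1ccc(F)c(F)c1)c1cnc2c(F)cccc2c1-c1cccc(F)c1`, gives 1.28 mL/min in this assay.

Among the three measured compounds, compound 1 has the lowest number in this assay: the step of a 2.8-fold higher number from compound 1 to compound 2 (0.44 log units; beyond the scatter) and the step of a 4.6-fold higher number from compound 1 to compound 3 (0.66 log units; beyond the scatter) both lie beyond the scatter, while the step of a 1.6-fold higher number from compound 2 to compound 3 (0.22 log units; within the scatter) does not. All three measured steps alter the aryl on the core carbon, not the aryl on the sulfonyl sulfur.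

The unmeasured compound 4, `O=S(=O)(c1cc(F)cc(F)c1)c1cnc2c(F)cccc2c1-c1ccc(Cl)cc1`, differs from compound 1 only on the sulfonyl side: 3,5-difluorophenyl in place of 3,4-difluorophenyl on a sulfonyl sulfur. Among the compounds with values here, none of the measured steps touches this position, so no step in the data speaks directly to it. The change keeps the same atoms and the same count of fluorines on the ring, only rearranged, so the author expects no step beyond the scatter in this assay from compound 1, and the estimate a 1.1-fold higher number from compound 1 to compound 4 (0.06 log units; within the scatter) reflects that.

Compound 4 is therefore expected to give 0.32 mL/min in this assay, within a range from 0.15 mL/min to 0.7 mL/min.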

Compound 4, intrinsic clearance in a liver preparation (reported as CLH), per the amount of preparation that the assay uses: 0.73 mL/min
For compound 4 the middle estimate is 2.3-fold (0.36 log units) below the measured one, and the stated range ends below it.
By their numbers in this assay, from the lowest: compound 1; then compounds 4, 2 and 3 (each within the scatter of the next).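

Swapping 3,4-difluorophenyl for 3,5-difluorophenyl on the sulfonyl sulfur gives a 2.6-fold higher number from compound 1 to compound 4 (0.42 log units; beyond the scatter) in this assay, the first reading at this position among the compounds shown. Under HOW the two groups are counted they match, with the same carbon and fluorine atoms and the same aromatic ring, so rearranging the two fluorines on that ring is enough here to carry the number beyond the scatter, and the sulfonyl side can no longer be treated as a place where such a rearrangement passes unnoticed in this series. What lies behind the step remains unexplained, as no measurement shown here bears on it.

The compounds shown leave open whether the same rearrangement would give a step of similar size on the rest of compound 2 or compound 3, since this single pair is the only reading of the change. They also leave open how this assay would respond to other groups on the sulfonyl sulfur, such as a plain phenyl, a 3,4-dichlorophenyl or a methoxyphenyl.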